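A few compounds are considered here, and "the series" means these few. Any claim that something is new, unique, unknown or untested is made for them only; others in the source may bear on it.

In a functional assay on cells (T-cell line, Homo sapiens) for inhibition (on this read-out lower numbers stand for stronger inhibition and higher numbers for weaker inhibition), compound 1 `COc1ccc(CCCN2CCC(COCc3ccc(Cl)cc3)CC2)cc1` gives 500 nM and compound 2 `COc1ccc(CCCN2CCC(COC(c3ccccc3)c3ccc(Cl)cc3)CC2)cc1` gives 200 nM. The step between them, a 2.5-fold lower number from compound 1 to compound 2 (0.40 log units; beyond the scatter), puts phenyl in place of hydrogen on a saturated chain carbon bound to an aromatic carbon and an oxygen on a saturated carbon. Compound 3 `Cc1ccc(CCCN2CCC(COC(c3ccccc3)c3ccccc3)CC2)cc1` gives 200 nM, level with compound 2, and its number is lower than that of compound 1.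

Compound 4 `CCCN1CCC(COC(c2ccccc2)c2ccccc2)CC1` departs from compound 3 at a single place: hydrogen in place of 4-methylphenyl on a saturated chain carbon, three bonds along the chain from an amine nitrogen in a ring. In short, 3-(4-methylphenyl)propyl gives way to propyl. Among the measured compounds shown here, no measured step touches this place, so the data hold no direct guide to the change. For the measured compounds named here, the only step available is the modest one from compound 1 to compound 2, a 2.5-fold lower number from compound 1 to compound 2 (0.40 log units; beyond the scatter), where a gained phenyl went with a lower number, though elsewhere in the molecule. Here a ring of the same kind is lost, so a higher number is expected, and the size remains uncertain. Going by the values given here, the expected change in this assay is a 10-fold higher number from compound 3 to compound 4 (1.00 log units; beyond the scatter), larger than the one measured step. For compound 4 the estimated value is 2000 nM, with an expected range of 500 nM to 10000 nM.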

Compound 4, half-maximal inhibitory concentration: 17800 nM
Compound 4: middle estimate off by 8.9-fold (0.95 log units), on the low side; the whole stated range lies below it.
By their numbers in this assay, from the lowest: compounds 2 and 3 (each within the scatter of the next); then compound 1; then compound 4.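

In this assay, among the compounds shown here, the step of an 89-fold higher number from compound 3 to compound 4 (1.95 log units; beyond the scatter) shows that the place on the saturated chain carbon, three bonds along the chain from an amine nitrogen in a ring, bears heavily on the number, which the earlier compounds could not show because none of them varied there. The loss of 4-methylphenyl, which turns 3-(4-methylphenyl)propyl into propyl, is a large change, whereas the gain of phenyl elsewhere in the molecule, a 2.5-fold lower number from compound 1 to compound 2 (0.40 log units; beyond the scatter), is only a modest one. No measurement available here bears on why this aryl group matters so much to the number.

The compounds shown leave open whether the result depends on the aromatic ring itself or simply on the length and bulk of the group at the end of the chain: propyl differs from 3-(4-methylphenyl)propyl in both, and a cyclohexyl group or a plain hexyl chain in that place would help to separate the two. They also leave open how far the ring can be changed, for instance to a pyridine, with the number staying close to that of compound 3.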